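A few compounds are considered here, and "the series" means these few. Any claim that something is new, unique, unknown or untested is made for them only; others in the source may bear on it.

In a physicochemical assay for solubility, in phosphate buffer, at pH 7.4 (a higher number here means a more soluble compound, a lower number a less soluble compound), compound 1 (`CCOC(=O)c1c(-c2cccc(OC)c2)[nH]c2cc(OC)ccc2c1=O`) gives > 100000 nM and that is a limit of the assay, not a number. Compound 2 (`CCOC(=O)c1c(-c2ccccc2Cl)[nH]c2cccc(OC)c2c1=O`) gives > 100000 nM and that too is a limit. The measurements so far therefore show one shared limit (the limit of > 100000 nM in this assay, at which 2 of the 2 values shown sit) and compound 1 cannot be ranked against compound 2.

Compound 3 (`CCOC(=O)c1c(-c2ccc(Cl)cc2)[nH]c2cc(OC)ccc2c1=O`) keeps the core of compound 1 but carries 4-chlorophenyl in place of 3-methoxyphenyl on an aromatic carbon next to the ring nitrogen (4-chlorophenyl in place of 3-methoxyphenyl on an aromatic carbon). Among the compounds with values here, no measured pair shows what such a swap does, so the only guide is compound 2, which has a chlorophenyl group and gives > 100000 nM as its limit. In this assay no step beyond the usual scatter is therefore expected, and the estimated step is an at least 1.1-fold lower number from compound 1 to compound 3 (0.04 log units; that floor lies within the scatter) in size. The estimate for compound 3 is 90000 nM with an expected range from 30000 nM to 150000 nM and the reading may again be only a limit.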

Compound 3, solubility: 3000 nM
Estimate against measurement, compound 3: 30-fold (1.48 log units) above; the measured number lies below the stated range.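

Within the data shown here, compound 3 is the first compound here to give a number rather than a limit. It shows that the group on the aromatic carbon next to the ring nitrogen can matter a great deal in this assay: with the rest of the core of compound 1 unchanged, 4-chlorophenyl in place of 3-methoxyphenyl gives an at least 33-fold lower number from compound 1 to compound 3 (1.52 log units; beyond the scatter). The true size of this step remains unknown because only its lower bound can be read, with compound 1 sitting at a limit: the limit of > 100000 nM in this assay, at which 2 of the 3 values shown sit.

The swap changes both the kind of substituent on the phenyl ring and its place, and the compounds shown do not separate the two, as neither 3-chlorophenyl nor 4-methoxyphenyl appears on this core. They also leave open how a phenyl ring carrying an amine or a carboxylic acid would read at this carbon.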